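Acylurea to chloroalkyl amide: a blind step

This account rests on a few compounds, and the source may have more. Where it says the series, first, only, none or still open, it means among the compounds named here.

Measured so far in a functional assay on M21 cells (Homo sapiens) for antiproliferative activity, with a stated time of 48 h; on this read-out higher numbers stand for weaker inhibition and lower numbers for stronger inhibition:
compound 1 `CCCCCc1cccc(NC(=O)NC(=O)CCl)c1`, 3500 nM
compound 2 `CCCCC(OC)c1cccc(NC(=O)NC(=O)CCl)c1`, 4200 nM
compound 3 `O=C(CCl)Nc1ccc(I)cc1`, 5100 nM

Compound 2 stands second highest of the three numbers in this assay, with compound 1 nearest and compound 3 furthest; both gaps are within the scatter, so the three compounds cannot be told apart on these data. For the measured compounds named here, the only step between two measured compounds is a 1.2-fold higher number from compound 1 to compound 2 (0.08 log units; within the scatter), which concerns the methoxy on the saturated chain carbon and leaves the acyl part untouched.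

Compound 4 `CCCCC(OC)c1cccc(NC(=O)CCCCl)c1` differs from compound 2 in that acyl part: 3-chloropropyl in place of ((chloromethyl)carbonyl)amino on a carbonyl carbon. Going by the values given here, no measured step bears on this change; compound 3 carries the chloroacetyl amide directly on the ring without the urea nitrogen and sits in the same band as compounds 1 and 2, but no step to it is available. The expectation for compound 4 therefore rests on no comparison and is set near the band of the measured compounds, with a wide range and a lean toward a weaker number; the step of a 1.7-fold higher number from compound 2 to compound 4 (0.22 log units; within the scatter) is an estimate only. Compound 4 is expected to give about 7000 nM in this assay, between 2000 nM and 25000 nM.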

Compound 4, half-maximal inhibitory concentration: > 100000 nM
Compound 4: a limit, no number; the forecaster's own chance of this, stated with the estimate: 20%; at least 14-fold (1.15 log units) between middle value and limit.
By their numbers in this assay, from the lowest: compounds 1, 2 and 3 (each within the scatter of the next). At a limit, above all of these: compound 4.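

In this assay compound 4 gives > 100000 nM, which is a limit of the assay and not a number. The acyl part on the carbonyl carbon now carries a large step, an at least 23-fold higher number from compound 2 to compound 4 (1.37 log units; beyond the scatter), the first beyond the scatter in this set, whereas the methoxy change on the saturated chain carbon gave only a 1.2-fold higher number from compound 1 to compound 2 (0.08 log units; within the scatter); replacing ((chloromethyl)carbonyl)amino with 3-chloropropyl, which leaves 0 hydrogen-bond donors and 0 hydrogen-bond acceptors in the entering group, is therefore not tolerated in this series, at least on the background of compound 2. The true size of the step stays bounded on one side only, and compound 4 is the only compound in the set that reaches such a limit: the limit of > 100000 nM in this assay, at which 1 of the 4 values shown sits.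

Still open, going by these compounds, is which part of the change carries the step, since the amino nitrogen, the second carbonyl and the chlorine-bearing chain all change together between these two compounds. An acylurea with a plain methyl in place of chloromethyl, or a butanoyl amide without chlorine, would begin to separate the role of the chlorine from that of the urea nitrogen.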